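Swapping Fluoro for Amino on the Urea Side Ring

This account rests on a few compounds, and the source may have more. Where it says the series, first, only, none or still open, it means among the compounds named here.

Of the compounds shown here, three sharing one core have been tested in an ADME assay on HEK293 cells (Homo sapiens) for cytotoxicity, with a stated time of 72 h; a higher number here means that more compound is needed for the effect, a lower number that less compound is needed. Compound 1 `Cc1cc(NC(=O)Nc2cc(F)ccc2F)c2ccccc2n1` gives 12000 nM, and compound 3 `Cc1cc(NC(=O)Nc2ccc(F)cc2F)c2ccccc2n1` gives 10000 nM. Compound 2 `Cc1cc(NC(=O)Nc2ccccc2F)c2ccccc2n1` reaches only > 25000 nM, which is a limit of the assay rather than a number, matching (the limit of > 25000 nM in this assay, at which 1 of the 3 values shown sits). Taking one fluoro away gives an at least 2.0-fold higher number from compound 1 to compound 2 (0.31 log units; beyond the scatter), and adding one fluoro gives an at least 2.5-fold lower number from compound 2 to compound 3 (0.39 log units; beyond the scatter). Compound 4 `Cc1cc(NC(=O)Nc2ccccc2N)c2ccccc2n1` differs from compound 2 by amino in place of fluoro on an aromatic carbon. Both measured steps concern fluoro and hydrogen, not amino, so they offer no direct guide, and no step beyond the scatter is expected in this assay. Compound 4 is therefore estimated at 25000 nM, between 10000 nM and 60000 nM. That amounts to an expected a number no higher from compound 2 to compound 4 (the limit leaves the size open).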

Compound 4, half-maximal effective concentration: > 25000 nM
Compound 4 was reported as a limit (the forecaster's own chance of this, stated with the estimate: 55%); the middle value lies on the limit itself.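

No step can be read between compound 2 and compound 4, because each result is a limit and not a number: the limit of > 25000 nM in this assay, at which 2 of the 4 values shown sit. The compounds shown leave open how far compound 4 and compound 2 truly differ in this assay when amino replaces fluoro.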